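The source may report more compounds than this note shows. Statements on the series, on what has been measured and on what is new or still open speak of the compounds shown alone.

Compound 1 `CCC[C@@H](OC(C)=O)C1=C(Br)C(=C(Br)Br)OC1=O`: 0.3 ug/mL
Compound 2 `CCC[C@@H](OC(C)=O)C1=C(Br)/C(=C/Br)OC1=O`: 0.8 ug/mL
Compound 3 `CCC[C@@H](O)C1=C(Br)C(=C(Br)Br)OC1=O`: 0.5 ug/mL

In a functional assay on KB cells (Homo sapiens) for cytotoxicity (on this read-out higher numbers stand for an effect only at larger amounts of compound and lower numbers for an effect already at smaller amounts), compound 2 gives the highest of the three numbers; its gap to compound 3 lies within the scatter, while its gap to compound 1 lies beyond it. Compound 4 `CCCCC1=C(Br)/C(=C/Br)OC1=O` differs from compound 2 in one place: hydrogen in place of acetoxy on a saturated chain carbon bound to a double-bonded ring carbon and a saturated chain carbon. For the measured compounds named here, the only measured step that touches this part of the molecule is a 1.7-fold higher number from compound 1 to compound 3 (0.22 log units; within the scatter), which exchanged the acetyl alone and left the oxygen in place; no measured pair removes the whole acetoxy. With that step within the scatter, compound 4 is expected to show a 1.3-fold higher number from compound 2 to compound 4 (0.10 log units; within the scatter) in this assay. Compound 4 is therefore estimated at 1 ug/mL, with a range from 0.4 ug/mL to 2.5 ug/mL.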

Compound 4, concentration for half-maximal effect: > 20 ug/mL
Compound 4: a limit, no number; the forecaster's own chance of this, stated with the estimate: 5%; at least 20-fold (1.30 log units) between middle value and limit.
By their numbers in this assay, from the lowest: compounds 1, 3 and 2 (each within the scatter of the next, the first and the last beyond it). At a limit, above all of these: compound 4.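

Putting hydrogen in place of acetoxy on this saturated chain carbon gives an at least 25-fold higher number from compound 2 to compound 4 (1.39 log units; beyond the scatter) in this assay, so this position matters far more than the exchange of the acetyl alone, a 1.7-fold higher number from compound 1 to compound 3 (0.22 log units; within the scatter), could show. Losing the acetyl while the oxygen stayed made no change beyond the scatter, whereas losing the whole acetoxy did. The reading for compound 4 is a limit and not a number: the limit of > 20 ug/mL in this assay, at which 1 of the 4 values shown sits.

On these data alone, whether an amine or a methoxy group at this place would keep the effect stays open. So does whether the same removal on the core of compound 1 would act alike.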